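Furan for pyrimidine at the biaryl terminus: intrinsic activity

The source may hold more compounds than are shown below. What is called first, only, known or untested is meant among the compounds shown, and "the series" means these compounds.

Compound 1 `COc1ccc(N2C[C@@H](C)N[C@@H](C)C2)cc1NS(=O)(=O)c1ccc(-c2ccncc2)cc1` is the reference point of this pair: in a functional assay for agonist activity at growth hormone secretagogue receptor type 1 (Homo sapiens), read by FLIPR (on this read-out higher numbers stand for larger maximal responses and lower numbers for smaller maximal responses), compound 1 gives 0.7. Compound 2 `COc1ccc(N2C[C@@H](C)N[C@@H](C)C2)cc1NS(=O)(=O)c1ccc(-c2cncnc2)cc1` carries pyrimidin-5-yl in place of pyridin-4-yl on the same aromatic carbon, and in this assay compound 2 gives 0.6. The step a number 0.10 lower from compound 1 to compound 2 (within the scatter) is the only measured one in the series. Of the two numbers recorded, compound 2 holds the smaller, but its nearest neighbour compound 1 is separated from it only by that step, which the scatter of the read-out covers.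

Compound 3 `COc1ccc(N2C[C@@H](C)N[C@@H](C)C2)cc1NS(=O)(=O)c1ccc(-c2ccc(C)o2)cc1` is not yet measured. Its difference from compound 2 is 5-methylfuran-2-yl in place of pyrimidin-5-yl on an aromatic carbon. Within the data shown here, the one step that bears on it, a number 0.10 lower from compound 1 to compound 2 (within the scatter), exchanged one six-membered heteroaryl for another at this position and stayed within the scatter. Among the measured compounds shown here, the present exchange brings in a five-membered ring with one oxygen and a methyl, a larger change in kind, yet no recorded step hints at a move beyond the scatter. For compound 3 the step of no change at the digits printed from compound 2 to compound 3 (within the scatter) is therefore expected to stay inside the usual spread, with compound 3 estimated at 0.6, between 0.4 and 0.8.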

Compound 3, intrinsic activity: the largest response reached, as a fraction of the reference agonist's: 1
Compound 3: middle estimate off by 0.40, on the low side, outside the stated range (above it).
By their numbers in this assay, from the lowest: compounds 2 and 1 (each within the scatter of the next); then compound 3.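

In this assay, the group on this aromatic carbon, para to a large group, proves able to shift the maximal response: the read-out is a number 0.40 higher from compound 2 to compound 3 (beyond the scatter), and it is a number 0.30 higher from compound 1 to compound 3 (beyond the scatter). The two six-membered heteroaryl groups had stayed within the scatter of each other, so compound 3 stands clear of both, and 5-methylfuran-2-yl is the only group shown here that moves the read-out beyond the scatter, although it has the same count of heavy atoms as pyrimidin-5-yl. No measurement at hand accounts for this step.

The compounds shown do not separate the contribution of the five-membered ring from that of its methyl, and furan-2-yl without the methyl, together with thiophen-2-yl, would divide those two questions. Going by these compounds, only the largest response is at hand, so whether potency at the receptor follows the same order remains open.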